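Thiophenylbenzamides against prostate cancer cells: predicting a sulfone analogue

The source may hold more compounds than are shown below. What is called first, only, known or untested is meant among the compounds shown, and "the series" means these compounds.

Measured compounds:
compound 1, `O=C(Nc1cccc(S(F)(F)(F)(F)F)c1)c1ccc(Sc2ccc(O)cc2)cc1`, 3320 nM
compound 2, `O=C(Nc1cccc(C(F)(F)F)c1)c1ccc(Sc2ccc(O)cc2)cc1`, 9660 nM
compound 3, `O=C(Nc1cccc(S(F)(F)(F)(F)F)c1)c1ccc(S(=O)(=O)c2ccc(O)cc2)cc1`, 3980 nM

In a functional assay on LNCaP cells (Homo sapiens) for antiproliferative activity, read by fluorescence and propidium iodide staining, with a stated time of 96 h (a higher number here means a weaker inhibitor, a lower number a stronger inhibitor), compound 1 gives 3320 nM. Moving to compound 2 brings a change (a group of 4 heavy atoms (1 carbon, 3 fluorine; no ring) in place of a group of 6 heavy atoms (5 fluorine, 1 sulfur; no ring), on an aromatic carbon), and the step is a 2.9-fold higher number from compound 1 to compound 2 (0.46 log units; beyond the scatter). Compound 3 differs from compound 1 by (4-hydroxyphenyl)sulfonyl in place of (4-hydroxyphenyl)sulfanyl on an aromatic carbon, and that step is a 1.2-fold higher number from compound 1 to compound 3 (0.08 log units; within the scatter). The unmeasured compound 4, `O=C(Nc1cccc(C(F)(F)F)c1)c1ccc(S(=O)(=O)c2ccc(O)cc2)cc1`, is related to compound 3 by a group of 4 heavy atoms (1 carbon, 3 fluorine; no ring) in place of a group of 6 heavy atoms (5 fluorine, 1 sulfur; no ring), on an aromatic carbon, which is the same change as that from compound 1 to compound 2; both occur on an aromatic carbon of a six-membered aromatic ring of carbon only, meta to a large group, so the place is the same.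

For the measured compounds named here, with only one earlier example of this change, the expectation for compound 4 rests on that single step together with the closeness of compound 1 and compound 3 in this assay. The expected step is a 2.8-fold higher number from compound 3 to compound 4 (0.44 log units; beyond the scatter), set beside the measured 2.9-fold higher number from compound 1 to compound 2 (0.46 log units; beyond the scatter). Compound 4 is therefore estimated to give 11000 nM, with a range from 5000 nM to 25000 nM.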

Compound 4, half-maximal inhibitory concentration: 10200 nM
Compound 4: middle estimate off by 1.1-fold (0.03 log units), on the high side; the measured number falls inside the stated range.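

In this assay, putting trifluoromethyl in place of the group of five fluorine atoms and one sulfur on the sulfonyl core gives a 2.6-fold higher number from compound 3 to compound 4 (0.41 log units; beyond the scatter), so the weakening first seen on the sulfanyl core appears here as well. The two steps agree in direction and size: the same change on two cores in this assay, a 2.9-fold higher number (0.46 log units; beyond the scatter) from compound 1 to compound 2 and a 2.6-fold higher number (0.41 log units; beyond the scatter) from compound 3 to compound 4, 1.1-fold (0.06 log units) apart, within the scatter of two such steps. This shows that, between these two cores and in this one assay, the change carried over with little loss of size, but it rests on just two matched pairs and shows neither why the step arises nor whether it would hold on any other core or in any other assay.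

The compounds shown leave open how other groups on that aromatic carbon, such as a nitrile, a tert-butyl group or a carboxylic acid, would compare with these two. They also leave open whether the same step would survive if an amine or a methoxy group replaced the hydroxyl of the (4-hydroxyphenyl) part.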